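The source may hold more compounds than are shown below. What is called first, only, known or untested is meant among the compounds shown, and "the series" means these compounds.

Measured compounds in a functional assay on the whole organism (strain Wistar) for inhibition, with Rattus norvegicus as the target, with stated times of 30 min and 3 h, at a dose of 20 mg/kg by the oral route; on this read-out higher numbers stand for more inhibition at the one dose given (going by the name of the read-out) and lower numbers for less inhibition:
Compound 1 `O=C(CCc1nnc(-c2ccccc2)o1)c1ccccc1` gives 29.4% in this assay.
Compound 2 `Cc1ccc(C(=O)CCc2nnc(-c3ccccc3)o2)cc1` gives 49.3% in this assay.
Compound 3 `O=C(CCc1nnc(COc2ccc3ccccc3c2)o1)c1ccccc1` gives 51% in this assay.

Compound 2 differs from compound 1 by methyl in place of hydrogen on an aromatic carbon, and in this assay this step gives a number 19.9 percentage points higher from compound 1 to compound 2 (beyond the scatter). Compound 3 and compound 2 lie within the scatter of each other; the difference between the core of compound 3 and the core of compound 1 is not broken down here. Compound 4 `Cc1ccc(C(=O)CCc2nnc(COc3ccc4ccccc4c3)o2)cc1` is not yet measured; it differs from compound 3 by methyl in place of hydrogen on an aromatic carbon, the same change at the same place as from compound 1 to compound 2. Among the measured compounds shown here, the step from compound 3 to compound 4 is expected to be a number 12 percentage points higher from compound 3 to compound 4 (beyond the scatter), taken somewhat smaller than the step from compound 1 to compound 2 because compound 3 already stands at 51% and only one earlier instance of the change is at hand. Compound 4 is thus estimated at 63%, within 48% to 78%.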

Compound 4, a percentage reported as inhibition, in the whole organism at one dose (the size of the read-out at that dose, not a potency): 49.4%
Beside the measured number, compound 4's estimate is 13.6 percentage points above it, within the range that was stated.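

In this assay the change from phenyl to 4-methylphenyl gives a number 1.6 percentage points lower from compound 3 to compound 4 (within the scatter) and so brings no measurable gain on this core. The change therefore does not carry over from the core of compound 1 to the core of compound 3 with the same size: the same change on two cores in this assay, a number 19.9 percentage points higher (beyond the scatter) from compound 1 to compound 2 and a number 1.6 percentage points lower (within the scatter) from compound 3 to compound 4, 21.5 percentage points apart, beyond the scatter of two such steps. This shows that the step depends on the core in this one pair, but two instances at a single dose give no general rule and do not show what sets the two cores apart.

Open, on these data alone, is whether a chlorine, a methoxy or an ethyl in the same place would also differ between the two cores. Also open, as far as these compounds go, is how an amine or a carboxylic acid there would read out on either core.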